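The source may report more compounds than this note shows. Statements on the series, on what has been measured and on what is new or still open speak of the compounds shown alone.

Measured so far in an ADME assay on MDBK cells (Bos taurus) for cytotoxicity, read by MTT assay; on this read-out higher numbers stand for lower toxicity in this test and lower numbers for higher toxicity in this test:
- Compound 1 `OC[C@@H]1[C@@H](O)[C@H](O)[C@@H](O)CN1CCCc1cccc(OC2CCCCC2)c1`: 390000 nM
- Compound 2 `CCC1CCC(OCCCCCCN2C[C@H](O)[C@@H](O)[C@H](O)[C@H]2CO)CC1`: > 500000 nM (a limit)
- Compound 3 `CCCCC1CCC(OCCCCCCN2C[C@H](O)[C@@H](O)[C@H](O)[C@H]2CO)CC1`: 190000 nM

Compound 2 gives no number in this assay, only the limit > 500000 nM. Going by the values given here, it is the one such reading among the three: the limit of > 500000 nM in this assay, at which 1 of the 3 values shown sits.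

Compound 4 `CCC1CCCCC1OCCCCCCN1C[C@H](O)[C@@H](O)[C@H](O)[C@H]1CO` has not yet been measured. It has the same atoms as compound 2, joined differently: a group of 8 heavy atoms (8 carbon; one six-membered non-aromatic ring of carbon only) in place of a group of 8 heavy atoms (8 carbon; one six-membered non-aromatic ring of carbon only), on an oxygen on a saturated carbon. The 4-ethylcyclohexyl group leaves, and an isomeric group of the same count enters, on an oxygen on a saturated carbon.

Among the compounds with values here, only one measured step bears on this, and only loosely: an at least 2.6-fold lower number from compound 2 to compound 3 (0.42 log units; beyond the scatter). That step puts ethyl in place of hydrogen on a saturated chain carbon, whereas compound 4 keeps the atoms of compound 2. Within the data shown here, compound 1 has no measured step to compound 2. Among the measured compounds shown here, a step as large as the one to compound 3 is therefore not expected, and any change is expected to be small, towards a lower number if it shows at all. The expected size is an at least 1.2-fold lower number from compound 2 to compound 4 (0.09 log units; that floor lies within the scatter). The assay may well report only a limit again. For compound 4 the estimated value is 400000 nM, with an expected range from 180000 nM to 800000 nM.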

Compound 4, half-maximal cytotoxic concentration: 450000 nM
Compound 4: middle estimate off by 1.1-fold (0.05 log units), on the low side; low and high end bracket the measured number.
By their numbers in this assay, from the lowest: compound 3; then compounds 1 and 4 (each within the scatter of the next). At a limit, above all of these: compound 2.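

In this assay, the exchange of the 4-ethylcyclohexyl group for an isomeric group of the same count, on an oxygen on a saturated carbon, is the first change shown that keeps the atoms of the compound unaltered, and it gives an at least 1.1-fold lower number from compound 2 to compound 4 (0.04 log units; that floor lies within the scatter). That floor lies within the scatter, so this rejoining of the same atoms shows no change that can be told from repeat measurement, whereas adding carbon to the chain gave an at least 2.6-fold lower number from compound 2 to compound 3 (0.42 log units; beyond the scatter), which lies beyond it. The true size of the step from the 4-ethylcyclohexyl compound stays unknown because compound 2 gives only a limit and not a number: the limit of > 500000 nM in this assay, at which 1 of the 4 values shown sits.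

Still open, on these data alone, is whether the two isomeric groups would differ at all if both compounds could be read as numbers in this assay. The compounds shown also leave open how an amine or a carboxylic acid on the six-membered ring of carbon only, or a propyl group in place of the ethyl, would read there.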